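Fluoro for methyl on the aryl ring of compound 2

The compounds below may be only part of what the source reports. "The series", "measured", "known", "first", "only" and "open" are said of these compounds alone.

Measured so far: compound 1 `C/C(=C\c1nc(-c2ccccc2)cs1)C(N)=O`, 3780 nM; compound 2 `C/C(=C\c1nc(-c2ccc(C)cc2)cs1)C(N)=O`, > 50000 nM.

In a functional assay on HO8910 cells (Homo sapiens) for cytotoxicity, read by CCK-8 assay, with a stated time of 24 h (a higher number here means a weaker inhibitor, a lower number a stronger inhibitor), compound 1 gives 3780 nM. For compound 2 the value is only a limit, (the limit of > 50000 nM in this assay, at which 1 of the 2 values shown sits). Compound 2 therefore stands at the weak end of the pair shown. Among the measured compounds shown here, the step of an at least 13-fold higher number from compound 1 to compound 2 (1.12 log units; beyond the scatter) is the sole measured step. Compound 3 `C/C(=C\c1nc(-c2ccc(F)cc2)cs1)C(N)=O` arises from compound 2 by fluoro in place of methyl on an aromatic carbon. For the measured compounds named here, no measured step bears directly on this change; only the large loss from hydrogen to methyl is known, so a move back toward compound 1 is expected. Compound 3 is estimated at 15000 nM (range 4000 nM to 50000 nM), a step of an at least 3.3-fold lower number from compound 2 to compound 3 (0.52 log units; beyond the scatter) expected.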

Compound 3, half-maximal inhibitory concentration: 4450 nM
Estimate against measurement, compound 3: 3.4-fold (0.53 log units) above; the range from low to high includes it.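

In this assay, fluoro in place of methyl on this aromatic carbon gives an at least 11-fold lower number from compound 2 to compound 3 (1.05 log units; beyond the scatter). Fluoro in place of hydrogen gives a 1.2-fold higher number from compound 1 to compound 3 (0.07 log units; within the scatter), so the position accepts a substituent and the loss seen with methyl does not extend to fluoro. The value of compound 2 is a limit of the assay, so the first step gives only a minimum size: the limit of > 50000 nM in this assay, at which 1 of the 3 values shown sits.

The compounds shown leave open how a larger halogen such as chloro, a methoxy group or an amine would behave at this position. They also leave open whether the same position tolerates fluoro when the primary amide is replaced by a carboxylic acid.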